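The source may report more compounds than this note shows. Statements on the series, on what has been measured and on what is new or still open speak of the compounds shown alone.

Working notes on the series. Compound 3 `ClCc1cccc(Cn2cnc3c(Cl)ncnc32)c1` stands second highest of the three numbers in a functional assay on CAKI-1 cells (Homo sapiens) for cytotoxicity, read by sulforhodamine B assay, with a stated time of 48 h (on this read-out higher numbers stand for lower toxicity in this test and lower numbers for higher toxicity in this test), where compound 3 gives 5620 nM; compound 2 `ClCc1ccccc1Cn1cnc2c(Cl)ncnc21` gives 9330 nM and compound 1 `ClCc1ccccc1Cn1cnc2c(Cl)nc(Cl)nc21` gives 3090 nM, both within the scatter of compound 3. Compound 4 `ClCc1cccc(Cn2cnc3c(Cl)nc(Cl)nc32)c1` differs from compound 3 by chloro in place of hydrogen on an aromatic carbon. For the measured compounds named here, the one measured step that bears on this is the reverse change, a 3.0-fold higher number from compound 1 to compound 2 (0.48 log units; beyond the scatter). Reading it backwards, a chloro entering in place of hydrogen on the shared core is expected to give a lower number in this assay, so compound 4 is estimated at 1870 nM, range 900 nM to 4500 nM. That estimate means a step of a 3.0-fold lower number from compound 3 to compound 4 (0.48 log units; beyond the scatter), expected to lie beyond the scatter.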

Compound 4, concentration lethal to 50% of the cells: 22900 nM
Compound 4: the middle estimate sits 12-fold (1.09 log units) below what was measured; measured number outside the range, above it.
By their numbers in this assay, from the lowest: compounds 1, 3 and 2 (each within the scatter of the next, the first and the last beyond it); then compound 4.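

Chloro in place of hydrogen on this aromatic carbon, between two ring nitrogen atoms, gives a 4.1-fold higher number from compound 3 to compound 4 (0.61 log units; beyond the scatter) in this assay, so the change has no single direction at this position. Its outcome depends on the rest of the molecule, with the same change running opposite ways on two cores: the same change on two cores in this assay, a 3.0-fold higher number (0.48 log units; beyond the scatter) from compound 1 to compound 2 and a 4.1-fold lower number (0.61 log units; beyond the scatter) from compound 4 to compound 3, 12-fold (1.09 log units) apart, beyond the scatter of two such steps

Two matched pairs cannot show how general this reversal is. From the compounds shown here alone, whether it is particular to chloro stays open, and an amine or a methoxy group at this position on both cores would test that.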